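Phenyl in Place of Methyl: Expecting Compound 4

This account rests on a few compounds, and the source may have more. Where it says the series, first, only, none or still open, it means among the compounds named here.

Compound 3 `COc1ccc(/C=C/c2cc(OC)cc(OC)c2/C=C/C(=O)c2ccc(C)cc2)cc1` gives 3.6 ug/mL in a functional assay on A549 cells (Homo sapiens) for antiproliferative activity, read by MTT assay, with a stated time of 48 h (a lower number here means a stronger inhibitor, a higher number a weaker inhibitor), the lowest of the three numbers. Compound 1 `COc1ccc(/C=C/c2cc(OC)cc(OC)c2/C=C/C(=O)c2ccccc2)cc1` gives 3.9 ug/mL, within the scatter of it, and the step of a 1.1-fold lower number from compound 1 to compound 3 (0.03 log units; within the scatter) is accordingly small. Compound 2 `COc1ccc(/C=C/c2cc(OC)cc(OC)c2/C=C/C(=O)c2cccc(Br)c2)cc1` gives 8.1 ug/mL, and the step of a 2.3-fold lower number from compound 2 to compound 3 (0.35 log units; beyond the scatter) is modest, as is a 2.1-fold higher number from compound 1 to compound 2 (0.32 log units; beyond the scatter). Compound 4 `COc1ccc(/C=C/c2cc(OC)cc(OC)c2/C=C/C(=O)c2ccc(-c3ccccc3)cc2)cc1` differs from compound 3 by phenyl in place of methyl on an aromatic carbon. Within the data shown here, no measured step places a phenyl on that ring, so the two modest steps are the only guide, and they suggest that changes on this aromatic ring move this assay little. Compound 4 is therefore expected to show a 1.3-fold higher number from compound 3 to compound 4 (0.10 log units; within the scatter), with an estimated 4.5 ug/mL in a range from 2 ug/mL to 11 ug/mL.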

Compound 4, half-maximal inhibitory concentration: 4.6 ug/mL
Compound 4: middle estimate off by 1.0-fold (0.01 log units), on the low side, within the range that was stated.
By their numbers in this assay, from the lowest: compounds 3, 1, 4 and 2 (each within the scatter of the next, the first and the last beyond it).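

The aromatic carbon that carries methyl in compound 3 also takes a whole phenyl ring in this assay, since the steps of a 1.3-fold higher number from compound 3 to compound 4 (0.11 log units; within the scatter) and a 1.2-fold higher number from compound 1 to compound 4 (0.07 log units; within the scatter) both lie within the scatter. The step of a 1.8-fold lower number from compound 2 to compound 4 (0.25 log units; within the scatter) lies within the scatter as well, although compound 2 stands beyond the scatter of both compound 1 and compound 3. No measurement given here bears on this result. The compounds shown leave open whether an amine or a carboxylic acid on that carbon would also stay within the scatter of compound 3.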